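A 2-hydroxyethyl group added to compound 3

A few compounds are considered here, and "the series" means these few. Any claim that something is new, unique, unknown or untested is made for them only; others in the source may bear on it.

Of the compounds shown here, three with a shared core have been tested in an ADME assay on microsomes (Mus musculus) for metabolic stability; on this read-out lower numbers stand for slow clearance and higher numbers for fast clearance. Compound 1 (`Cc1cc(C(F)(F)F)c2cccc(OCc3c(Cl)ccc(S(=O)(=O)N4CC[C@@H](N(C)C)C4)c3Cl)c2n1`) gives 867 mL/min/kg, compound 2 (`Cc1cc(C(F)(F)F)c2cccc(OCc3c(Cl)ccc(S(=O)(=O)N4CCCC4)c3Cl)c2n1`) gives 967 mL/min/kg and compound 3 (`Cc1cc(C(F)(F)F)c2cccc(OCc3c(Cl)ccc(S(=O)(=O)N4CCCCC4)c3Cl)c2n1`) gives 1000 mL/min/kg. These three numbers lie within the scatter of each other, so compound 3 stands level with the other two.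

Compound 4 (`Cc1cc(C(F)(F)F)c2cccc(OCc3c(Cl)ccc(S(=O)(=O)N4CCC(CCO)CC4)c3Cl)c2n1`) has not yet been measured. It departs from compound 3 in one place: 2-hydroxyethyl in place of hydrogen on a saturated ring carbon. This puts 2-hydroxyethyl in place of hydrogen on a saturated ring carbon, three ring bonds from the ring nitrogen.

Within the data shown here, three measured steps bear on this. Hydrogen in place of dimethylamino on a saturated ring carbon shows a 1.1-fold higher number from compound 1 to compound 2 (0.05 log units; within the scatter). Piperidin-1-yl in place of pyrrolidin-1-yl on a sulfonyl sulfur shows a 1.0-fold higher number from compound 2 to compound 3 (0.01 log units; within the scatter). The closest guide is a 1.2-fold higher number from compound 1 to compound 3 (0.06 log units; within the scatter), since it compares a ring that carries a side group with plain piperidin-1-yl. None of these steps involves 2-hydroxyethyl itself, so the evidence is indirect. No step beyond the scatter is therefore expected in this assay.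

The expected step is a 1.2-fold lower number from compound 3 to compound 4 (0.07 log units; within the scatter). For compound 4 the estimated value is 850 mL/min/kg, with an expected range from 450 mL/min/kg to 1300 mL/min/kg.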

Compound 4, clearance: 1080 mL/min/kg
For compound 4 the middle estimate is 1.3-fold (0.10 log units) below the measured one; measured number inside the range.
By their numbers in this assay, from the lowest: compounds 1, 2, 3 and 4 (each within the scatter of the next).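

Adding the 2-hydroxyethyl chain on a saturated ring carbon, three ring bonds from the ring nitrogen, gives a 1.1-fold higher number from compound 3 to compound 4 (0.03 log units; within the scatter) in this assay and so cannot be told apart from plain piperidin-1-yl. This position therefore accepts a side chain ending in a hydroxyl group without any measurable shift in this read-out. The other two comparisons agree, with 4-(2-hydroxyethyl)piperidin-1-yl in place of pyrrolidin-1-yl giving a 1.1-fold higher number from compound 2 to compound 4 (0.05 log units; within the scatter) and the same group in place of 3-(dimethylamino)pyrrolidin-1-yl giving a 1.2-fold higher number from compound 1 to compound 4 (0.10 log units; within the scatter) so all four groups on the sulfonyl sulfur stand level, and no measurement here bears on why that is so.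

From the compounds shown here alone, it remains open whether a carboxylic acid, an amine or a longer chain on this same ring carbon would give a step beyond the scatter. Going by these compounds, the four compounds differ only in the group on the sulfonyl sulfur, so the effect of a change elsewhere on the shared core also remains open.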